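The source may hold more compounds than are shown below. What is called first, only, known or untested is meant among the compounds shown, and "the series" means these compounds.

In a functional assay on A2780 cells (Homo sapiens) for inhibition, read by sulforhodamine B assay (a higher number here means a weaker inhibitor of growth, a lower number a stronger inhibitor of growth), compound 1 (`COc1ccc(-c2ccc(-c3ccc(-c4nc5cc(C)ccc5[nH]4)cc3)cc2)cc1OC`) gives 2130 nM, while compound 3 (`Cc1ccc2[nH]c(-c3ccc(-c4ccc(-c5ccccc5)cc4)cc3)nc2c1`) gives 41200 nM. Compound 2 (`Fc1ccc(-c2ccc(-c3ccc(-c4nc5ccccc5[nH]4)cc3)cc2)cc1`) gives 48200 nM, which lies within the scatter of the number for compound 3. Compound 3 therefore stands level with compound 2 and far from compound 1, which has the lowest number of the three.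

Compound 4 (`Cc1ccc2[nH]c(-c3ccc(-c4ccc(-c5ccc(F)cc5)cc4)cc3)nc2c1`) is compound 3 with a single change: fluoro in place of hydrogen on an aromatic carbon, para to a large group, (fluoro in place of hydrogen on an aromatic carbon). Among the measured compounds shown here, the one measured step touching that same phenyl group, a 19-fold higher number from compound 1 to compound 3 (1.29 log units; beyond the scatter), is large, but it concerns 3,4-dimethoxyphenyl rather than a lone fluoro, so it offers little guidance here. More telling is compound 2, which already carries a 4-fluorophenyl group, although it differs from compound 3 elsewhere too, and still sits level with it. No change beyond the scatter is therefore expected, and the estimated step is a 1.0-fold lower number from compound 3 to compound 4 (0.01 log units; within the scatter). For compound 4 the expected value is 40000 nM, with an estimated range from 17000 nM to 85000 nM.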

Compound 4, concentration for 50% growth inhibition: 24600 nM
Beside the measured number, compound 4's estimate is 1.6-fold (0.21 log units) above it; measured number inside the range.
By their numbers in this assay, from the lowest: compound 1; then compounds 4, 3 and 2 (each within the scatter of the next).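

Fluoro in place of hydrogen on an aromatic carbon, para to a large group, gives a 1.7-fold lower number from compound 3 to compound 4 (0.22 log units; within the scatter) in this assay, the first direct reading of this change, and it leaves the number within the scatter. Adding a methyl group to the shared core also stays within the scatter, at a 2.0-fold lower number from compound 2 to compound 4 (0.29 log units; within the scatter), so neither single-atom-sized change separates these compounds. The swap of 3,4-dimethoxyphenyl for 4-fluorophenyl gives a 12-fold higher number from compound 1 to compound 4 (1.06 log units; beyond the scatter), so the large gap seen with phenyl remains with fluoro in place.

Whether one methoxy group alone would account for that gap stays open, as does the outcome of an amine or a carboxylic acid at the para carbon. No measurement shown here explains any of these steps.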